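Dimethylamino in Place of the Chain Hydroxyl on Compound 3

The source may report more compounds than this note shows. Statements on the series, on what has been measured and on what is new or still open speak of the compounds shown alone.

Compound 1 `CCCC(=O)Nc1ncc(-c2cccc(Cl)c2)c(-c2ccccc2)n1` carries a propylcarbonyl on the ring nitrogen of the shared core. In an assay on CHO cells for displacement of a labelled ligand from adenosine receptor A1 (Homo sapiens), read by scintillation counting, with a stated time of 1 h, tested at 1 uM (a higher number here means more inhibition at the concentration tested (going by the name of the read-out), a lower number less inhibition), compound 1 gives > 80%, which is a limit of the assay and not a number. Compound 2 `C#CCNc1ncc(-c2cccc(Cl)c2)c(-c2ccccc2)n1` gives 76% in this assay. Compound 3 `OCCCNc1ncc(-c2cccc(Cl)c2)c(-c2ccccc2)n1` gives > 80% in this assay, again a limit of the assay. The measured steps read a number at least 4 percentage points lower from compound 1 to compound 2 (that floor lies within the scatter) and a number at least 4 percentage points higher from compound 2 to compound 3 (that floor lies within the scatter), while a step that the two limits leave unreadable from compound 1 to compound 3 cannot be sized since (the limit of > 80% in this assay, at which 2 of the 3 values shown sit).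

Compound 3 thus stands at the upper limit shown, alongside compound 1. Compound 4 `CN(C)CCNc1ncc(-c2cccc(Cl)c2)c(-c2ccccc2)n1` differs from it by dimethylamino in place of hydroxymethyl on a saturated chain carbon, two bonds along the chain from a nitrogen on an aromatic ring. Within the data shown here, no measured step exchanges a hydroxyl for an amine; only the step from compound 2 to compound 3 touches the same chain carbon, and it was within the scatter. With all three measured values sitting high, compound 4 is expected to stay high, with an estimated 78% and a range of 58% to 90%. The expected step of a number at least 2 percentage points lower from compound 3 to compound 4 (that floor lies within the scatter) is therefore not beyond the scatter.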

Compound 4, a percentage reported as inhibition, at one concentration (the size of the read-out at that concentration, not a potency): 52%
The estimate for compound 4 lay 26 percentage points above the measured number, outside the stated range (below it).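

In this assay the chain end of this series no longer appears indifferent: dimethylamino in place of hydroxymethyl, on a saturated chain carbon two bonds along the chain from a nitrogen on an aromatic ring, gives a number at least 28 percentage points lower from compound 3 to compound 4 (beyond the scatter), a change that goes beyond the scatter. Set against the propargyl group the same chain gives a number 24 percentage points lower from compound 2 to compound 4 (beyond the scatter), and set against the propylcarbonyl group it gives a number at least 28 percentage points lower from compound 1 to compound 4 (beyond the scatter), so compound 4 stands below all three earlier compounds. Two of these steps start from a limit of the assay and give only a floor: the limit of > 80% in this assay, at which 2 of the 4 values shown sit.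

The compounds shown cannot separate the arrival of dimethylamino from the loss of the hydroxyl, a question that a primary amine or a methyl ether on the same chain would address. They also leave open how dimethylamino reads on a longer chain.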